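From a Benzyl Amide to an Anilide Ether

The source may report more compounds than this note shows. Statements on the series, on what has been measured and on what is new or still open speak of the compounds shown alone.

Compound 1 `COc1ccc2nc(C)cc(OCC(=O)NCc3cc(C)cc(C)c3)c2c1` was tested in a toxicity assay on HepG2 cells (Homo sapiens) for inhibition, read by CellTiter-Glo, with a stated time of 48 h; a lower number here means a stronger inhibitor, a higher number a weaker inhibitor. Compound 1 gives only a limit there, > 100000 nM, so no number is known for it. Compound 2 `COc1ccc2nc(C)cc(NCC(=O)Nc3cc(C)cc(C)c3)c2c1` differs from compound 1 in two places; in this assay compound 2 gives 6310 nM. Compound 3 `COc1ccc2nc(C)cc(OCC(=O)Nc3ccc(Cl)c(OC)c3)c2c1` carries 4-chloro-3-methoxyphenyl in place of 3,5-dimethylbenzyl on an amide-type nitrogen. Within the data shown here, no measured step isolates this change, and the limit for compound 1 the limit of > 100000 nM in this assay, at which 1 of the 2 values shown sits, leaves the starting point open. Compound 3 is expected to be somewhat stronger, a step of an at least 3.3-fold lower number from compound 1 to compound 3 (0.52 log units; beyond the scatter). Compound 3 is estimated at 30000 nM, with a range from 8000 nM to 100000 nM.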

Compound 3, half-maximal inhibitory concentration: > 100000 nM
Compound 3 was reported as a limit; the forecaster's own chance of this, stated with the estimate: 40%; middle value at least 3.3-fold (0.52 log units) from the limit.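

In this assay, among these compounds, compound 3 gives > 100000 nM, a limit and not a number; compound 1 is also a limit, so no step between these two compounds can be read. From the compounds shown here alone, whether 4-chloro-3-methoxyphenyl in place of 3,5-dimethylbenzyl changes the strength of inhibition at all stays open.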